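A few compounds are considered here, and "the series" means these few. Any claim that something is new, unique, unknown or untested is made for them only; others in the source may bear on it.

Measured compounds:
compound 1 `O=C(c1ccc(-c2nc(-c3cccc(C(F)(F)F)c3)no2)s1)C(F)(F)F` — 320 nM
compound 2 `O=C(c1ccc(-c2nc(-c3cccnc3)no2)s1)C(F)(F)F` — 70 nM

In an assay for inhibition of histone deacetylase 4 (Homo sapiens) (a lower number here means a stronger inhibitor, a higher number a weaker inhibitor), compound 2 gives 70 nM, the lowest of the two numbers recorded. Its nearest neighbour is compound 1, which in this assay gives 320 nM, a gap that lies beyond the scatter of repeated measurements. For the measured compounds named here, no single-point step between measured compounds is available, so the two values can only be set side by side.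

Compound 3 `Cc1cccc(-c2noc(-c3ccc(C(=O)C(F)(F)F)s3)n2)c1` has not yet been measured. It differs from compound 2 in one place: 3-methylphenyl in place of pyridin-3-yl on an aromatic carbon. Compound 1 carries a carbon-only ring at this same place and gives 320 nM, so compound 3 is expected to land between the two measured compounds. The step of a 2.6-fold higher number from compound 2 to compound 3 (0.41 log units; beyond the scatter) is expected to be a moderate weakening, beyond the scatter. Compound 3 is estimated at 180 nM, within a range from 70 nM to 450 nM.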

Compound 3, half-maximal inhibitory concentration: 280 nM
Compound 3: the middle estimate sits 1.6-fold (0.19 log units) below what was measured; low and high end bracket the measured number.
By their numbers in this assay, from the lowest: compound 2; then compounds 3 and 1 (each within the scatter of the next).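

In this assay, for the compounds shown here, setting 3-methylphenyl in place of pyridin-3-yl on the aromatic carbon gives the first single-place reading at this position (a 4.0-fold higher number from compound 2 to compound 3 (0.60 log units; beyond the scatter)), and the step lies beyond the scatter. Exchanging trifluoromethyl for methyl on the carbon-only ring leaves the number within the scatter (a 1.1-fold lower number from compound 1 to compound 3 (0.06 log units; within the scatter)), so these two groups cannot be told apart here, and compound 1 and compound 3 both stand apart from compound 2, the one compound shown with pyridin-3-yl at this place. Nothing available explains this difference.

The compounds shown leave open whether the step from pyridin-3-yl follows from the ring nitrogen or from the added methyl. An unsubstituted phenyl would separate the two, and a pyridin-3-yl carrying an amine or a methoxy group would show how far substitution is tolerated in this assay.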